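Ester chain shortening in an iridoid glycoside series

The compounds below may be only part of what the source reports. "The series", "measured", "known", "first", "only" and "open" are said of these compounds alone.

Among the compounds with values here, compound 2 `CCCCCCCCCCCC(=O)OC[C@H]1O[C@@H](O[C@@H]2OC=C(C(=O)OC)[C@H]3C[C@H](OC(C)=O)[C@H](C)[C@@H]23)[C@H](OC(C)=O)[C@@H](OC(C)=O)[C@@H]1OC(C)=O` is the only member of the set with a number in a functional assay on COLO 320 cells (Homo sapiens) for cytotoxicity, read by MTT assay, with a stated time of 4 h; on this read-out higher numbers stand for weaker inhibition and lower numbers for stronger inhibition: compound 2 gives 0.04 ug/mL. Compound 1 `COC(=O)C1=CO[C@@H](O[C@@H]2O[C@H](CO)[C@@H](OC(C)=O)[C@H](OC(C)=O)[C@H]2OC(C)=O)[C@@H]2[C@@H](C)[C@@H](OC(C)=O)C[C@H]12` was reported as "not active" (no number reported) in this assay. Compound 3 `C=CC(=O)OC[C@H]1O[C@@H](O[C@@H]2OC=C(C(=O)OC)[C@H]3C[C@H](OC(C)=O)[C@H](C)[C@@H]23)[C@H](OC(C)=O)[C@@H](OC(C)=O)[C@@H]1OC(C)=O` carries the change (vinyl in place of undecyl on a carbonyl carbon). Within the data shown here, no measured pair shows this kind of step, so the size is open; a loss is expected, since compound 1, lacking any such chain, shows "not active" (no number reported) while compound 2 shows 0.04 ug/mL. The expected step for compound 3 in this assay is a 25-fold higher number from compound 2 to compound 3 (1.40 log units; beyond the scatter). Compound 3 is estimated at 1 ug/mL, within 0.1 ug/mL to 10 ug/mL.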

Compound 3, half-maximal inhibitory concentration: "not active" (no number reported)
Compound 3 has no reported number here; no gap can be computed for the estimate.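

Within the data shown here, compound 3 carries no number in this assay and no step from compound 2 can be read. The compounds shown leave open how activity changes with ester chains between vinyl and undecyl. No measurement shown bears on a cause for this result.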